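A few compounds are considered here, and "the series" means these few. Any claim that something is new, unique, unknown or untested is made for them only; others in the source may bear on it.

Compound 1 `COc1ccc(CNc2ncnc3c2ncn3C2CCCCO2)cc1` carries a single methoxy group on a six-membered aromatic ring of carbon only. In an ADME assay on K562 cells (Homo sapiens) for cytotoxicity, with a stated time of 72 h (a lower number here means a stronger inhibitor, a higher number a weaker inhibitor), compound 1 gives > 100000 nM, which is a limit of the assay rather than a number. Compound 2 `COc1ccc(CNc2ncnc3c2ncn3C2CCCCO2)cc1OC` differs from it by methoxy in place of hydrogen on an aromatic carbon. In this assay compound 2 gives > 100000 nM, again a limit. The step from compound 1 to compound 2 is thus a step that the two limits leave unreadable from compound 1 to compound 2. Compound 3 `COc1cccc(CNc2ncnc3c2ncn3C2CCCO2)c1` has another core; how its core differs from that of compound 1 is not broken down here. In this assay compound 3 gives > 100000 nM, also a limit. Compound 4 `COc1cc(CNc2ncnc3c2ncn3C2CCCO2)cc(OC)c1` is not yet measured and differs from compound 3 by methoxy in place of hydrogen on an aromatic carbon. This is the same kind of change as from compound 1 to compound 2, but the surroundings differ: there the new methoxy sits ortho to a methoxy group and meta to a large group, here meta to a large group and meta to a methoxy group. Because (the limit of > 100000 nM in this assay, at which 3 of the 3 values shown sit), the earlier step gives no readable size. The step from compound 3 to compound 4 is expected to be a number no higher from compound 3 to compound 4 (the limit leaves the size open) because of the limit of > 100000 nM in this assay, at which 3 of the 3 values shown sit. Compound 4 is expected to give 100000 nM in this assay, most likely only as a limit.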

Compound 4, half-maximal inhibitory concentration: > 100000 nM
Compound 4: a limit, no number; the forecaster's own chance of this, stated with the estimate: 85%; the middle value lies on the limit itself.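

In this assay compound 4 gives > 100000 nM, which is a limit of the assay and not a number. Compound 3 also sits at a limit, so no size can be read for the step between compound 3 and compound 4: the limit of > 100000 nM in this assay, at which 4 of the 4 values shown sit.

The compounds shown leave open how strongly any of them acts in this assay, and whether methoxy in place of hydrogen on an aromatic carbon changes that at all.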